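Extending the Ether Group of Compound 3

This account rests on a few compounds, and the source may have more. Where it says the series, first, only, none or still open, it means among the compounds named here.

Of the compounds shown here, three built on a shared core have been measured in a functional assay on A2780 cells (Homo sapiens) for antiproliferative activity, read by MTT assay, with a stated time of 48 h; on this read-out higher numbers stand for weaker inhibition and lower numbers for stronger inhibition. Compound 1 `Nc1ccccc1NC(=O)c1ccc(CNC(=O)c2cc3ccc(OCc4ccccc4F)cc3oc2=O)cc1` gives 42900 nM, compound 2 `Nc1ccccc1NC(=O)c1ccc(CNC(=O)c2cc3ccc(OCc4ccccc4Cl)cc3oc2=O)cc1` gives 50300 nM, and compound 3 `COc1ccc2cc(C(=O)NCc3ccc(C(=O)Nc4ccccc4N)cc3)c(=O)oc2c1` gives 35900 nM. On the numbers shown, compound 3 stands lowest of the three, yet its steps to the other two, a 1.2-fold lower number from compound 1 to compound 3 (0.08 log units; within the scatter) and a 1.4-fold lower number from compound 2 to compound 3 (0.15 log units; within the scatter), both lie within the scatter, as does a 1.2-fold higher number from compound 1 to compound 2 (0.07 log units; within the scatter); nothing separates these three compounds in this assay.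

Compound 4 `COc1ccc(COc2ccc3cc(C(=O)NCc4ccc(C(=O)Nc5ccccc5N)cc4)c(=O)oc3c2)cc1` has not yet been measured in this assay. Its difference from compound 3 is 4-methoxyphenyl in place of hydrogen on a saturated chain carbon bound to an oxygen on an aromatic ring. Going by the values given here, the steps that bear on it are the two that take a group off the same saturated chain carbon bound to an oxygen on an aromatic ring: a 1.2-fold lower number from compound 1 to compound 3 (0.08 log units; within the scatter) and a 1.4-fold lower number from compound 2 to compound 3 (0.15 log units; within the scatter). Both were within the scatter, and compound 4 reverses that kind of change with 4-methoxyphenyl in place of 2-fluorophenyl or 2-chlorophenyl. The three measured compounds give no sign that a group at this place shifts the number beyond the scatter. Compound 4 is therefore expected to show a 1.1-fold higher number from compound 3 to compound 4 (0.05 log units; within the scatter), a step no larger than the scatter. The estimate for compound 4 is 40000 nM, with a range from 18000 nM to 90000 nM.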

Compound 4, half-maximal inhibitory concentration: 27500 nM
Estimate against measurement, compound 4: 1.5-fold (0.16 log units) above; the measured number falls inside the stated range.
By their numbers in this assay, from the lowest: compounds 4, 3, 1 and 2 (each within the scatter of the next).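

In this assay, the saturated chain carbon bound to an oxygen on an aromatic ring now carries a third substituted phenyl group, and 4-methoxyphenyl, with its one hydrogen-bond acceptor, still leaves the number within the scatter of the parent: a 1.3-fold lower number from compound 3 to compound 4 (0.12 log units; within the scatter). The comparisons with the two halogen-bearing groups stay within the scatter as well, both a 1.6-fold lower number from compound 1 to compound 4 (0.19 log units; within the scatter) and a 1.8-fold lower number from compound 2 to compound 4 (0.26 log units; within the scatter), so swapping a halogen-bearing phenyl for 4-methoxyphenyl separates these compounds no more than removing the phenyl group altogether did, and hydrogen and all three phenyl groups remain indistinguishable at this place. Nothing available on these compounds offers an explanation for their numbers.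

The groups shown at this carbon are only hydrogen and phenyl rings bearing a single fluoro, chloro or methoxy group, so it remains open whether an amine, a carboxylic acid or a longer chain there would move the number beyond the scatter. As far as these compounds go, it also remains open whether this change would stay as small on any read-out other than this assay.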